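This account rests on a few compounds, and the source may have more. Where it says the series, first, only, none or still open, it means among the compounds named here.

Three compounds share a common core and differ only in the group carried on the benzylic carbon bound to the amine nitrogen. Compound 1 `CC(C)(C)c1ccc(CNCCCNS(=O)(=O)c2cc(C(F)(F)F)cc(C(F)(F)F)c2)cc1` gives 2000 nM in a functional assay on HT-29 cells (Homo sapiens) for inhibition, read by MTT assay, with a stated time of 72 h; on this read-out lower numbers stand for stronger inhibition of growth and higher numbers for weaker inhibition of growth. Compound 2 `O=S(=O)(NCCCNCC1COc2ccccc2O1)c1cc(C(F)(F)F)cc(C(F)(F)F)c1` gives 2200 nM, and compound 3 `O=S(=O)(NCCCNCc1ccc(C(F)(F)F)cc1)c1cc(C(F)(F)F)cc(C(F)(F)F)c1` gives 2900 nM. Compound 3 has the highest number of the three, but its separations from compound 2 (a 1.3-fold higher number from compound 2 to compound 3 (0.12 log units; within the scatter)) and from compound 1 (a 1.5-fold higher number from compound 1 to compound 3 (0.16 log units; within the scatter)) both lie within the scatter, as does a 1.1-fold higher number from compound 1 to compound 2 (0.04 log units; within the scatter), so the three stand together.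

Compound 4 `O=S(=O)(NCCCNCc1ccc(Br)cc1)c1cc(C(F)(F)F)cc(C(F)(F)F)c1` has not been measured. It differs from compound 3 by bromo in place of trifluoromethyl on an aromatic carbon. The step most closely bearing on this is a 1.5-fold higher number from compound 1 to compound 3 (0.16 log units; within the scatter), which also exchanges one substituent on that same aromatic carbon and stays within the scatter; the ring swaps a 1.1-fold higher number from compound 1 to compound 2 (0.04 log units; within the scatter) and a 1.3-fold higher number from compound 2 to compound 3 (0.12 log units; within the scatter) point the same way. The expected step in this assay from compound 3 is therefore a 1.0-fold higher number from compound 3 to compound 4 (0.01 log units; within the scatter), no shift beyond the scatter. Compound 4 is thus estimated at 3000 nM, within a range of 1500 nM to 6000 nM.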

Compound 4, concentration for 50% growth inhibition: 2200 nM
Estimate against measurement, compound 4: 1.4-fold (0.13 log units) above; the measured number falls inside the stated range.
By their numbers in this assay, from the lowest: compounds 1, 2, 4 and 3 (each within the scatter of the next).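

In this assay the exchange of trifluoromethyl for bromo on this aromatic carbon, para to a large group, gives a 1.3-fold lower number from compound 3 to compound 4 (0.12 log units; within the scatter) and so stays within the scatter. With a 1.1-fold higher number from compound 1 to compound 4 (0.04 log units; within the scatter) for bromo in place of tert-butyl, tert-butyl, trifluoromethyl and bromo have now all been seen on this carbon without any step leaving the scatter, and the ring exchange gives no change at the digits printed from compound 2 to compound 4 (within the scatter) as well. Nothing available explains why these numbers stay together.

On these data alone, whether an amine, a hydroxyl or a carboxylic acid on this carbon would stay with these numbers remains open. So does the response to a longer chain in the shared core.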